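The compounds below may be only part of what the source reports. "The series", "measured", "known", "first", "only" and "open" are said of these compounds alone.

Compound 1, `COC(=O)c1ccc(-c2cnc3ncn(C(C)c4cc5cccnc5cc4F)c3n2)cc1F`, is the starting point of this comparison. In an ADME assay on microsomes from liver (Rattus norvegicus) for metabolic stability, read by LC-MS, using NADPH, with stated times of 5 min and 30 min, tested at 1 uM (on this read-out lower numbers stand for slow clearance and higher numbers for fast clearance), compound 1 gives 125 uL/min, the lowest of the two numbers recorded, and its nearest neighbour is compound 2, `COC(=O)c1ccc(-c2cnc3ncn(C(C)c4c(F)cc5ncccc5c4F)c3n2)cc1F`, which in this assay gives 179 uL/min. Among the measured compounds shown here, the only measured step joining these two, a 1.4-fold higher number from compound 1 to compound 2 (0.16 log units; within the scatter), is therefore one that the usual scatter of repeated runs would cover.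

Compound 3, `CC(c1cc2cccnc2cc1F)n1cnc2ncc(-c3ccc(C(N)=O)c(F)c3)nc21`, has not yet been measured. It differs from compound 1 in one place: amino in place of methoxy on a carbonyl carbon. For the measured compounds named here, no measured step in this set involves the same change; the one step available concerns fluoro in place of hydrogen on an aromatic carbon, so it offers no direct guide to what amino in place of methoxy on a carbonyl carbon does here. In the absence of such a guide the expectation is a step of a 1.3-fold lower number from compound 1 to compound 3 (0.12 log units; within the scatter), a change that stays within the scatter. On that basis compound 3 is expected to give about 95 uL/min in this assay, with a plausible range from 45 uL/min to 190 uL/min.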

Compound 3, intrinsic clearance in a liver preparation (reported as CLH), per the amount of preparation that the assay uses: 85 uL/min
The estimate for compound 3 lay 1.1-fold (0.05 log units) above the measured number, and the stated range covers the measured number.
By their numbers in this assay, from the lowest: compounds 3, 1 and 2 (each within the scatter of the next, the first and the last beyond it).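

Exchanging methoxy for amino on a carbonyl carbon, which turns the methoxycarbonyl group of compound 1 into the carbamoyl group of compound 3, gives a small step in this assay (a 1.5-fold lower number from compound 1 to compound 3 (0.17 log units; within the scatter)). Among the compounds shown here, this is the first measured change at this position, as the earlier pair differed only by a fluoro on an aromatic carbon, and it shows that this exchange need not move the clearance reading beyond the usual scatter, even though amino brings a hydrogen-bond donor where methoxy brought a hydrogen-bond acceptor. The data available give no measured reason why the reading for this pair stays so close.

With a single replacement shown on this carbonyl carbon, it remains open whether a carboxylic acid, a nitrile or a methyl-substituted amide in place of the carbamoyl group would also stay within the scatter of compound 1. As far as these compounds go, it is equally open whether the fluoro change that links compound 1 to compound 2 would give a similarly small step when carbamoyl, rather than methoxycarbonyl, is present.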